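Amide nitrogen substituents on the shared core: compound 4

A few compounds are considered here, and "the series" means these few. Any claim that something is new, unique, unknown or untested is made for them only; others in the source may bear on it.

Compound 1 `CCn1c(C(=O)NCC(=O)OC)ccc1C(CC)(CC)c1ccc(OCS(=O)(=O)c2ccccc2)c(C)c1`: in a functional assay on MCF7 cells (Homo sapiens) for antiproliferative activity, read by MTT assay, with a stated time of 24 h (on this read-out lower numbers stand for stronger inhibition and higher numbers for weaker inhibition), compound 1 gives > 50000 nM, a limit of the assay.
Compound 2 `CCn1c(C(=O)N[C@@H](CO)C(C)C)ccc1C(CC)(CC)c1ccc(OCS(=O)(=O)c2ccccc2)c(C)c1`: in this assay compound 2 gives 18800 nM.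
Compound 3 `CCn1c(C(=O)N[C@@H](CC(=O)O)C(=O)O)ccc1C(CC)(CC)c1ccc(OCS(=O)(=O)c2ccccc2)c(C)c1`: in this assay compound 3 gives > 50000 nM, a limit of the assay.

For the measured compounds named here, compound 2 holds the only number in the set; the other two values sit at the limit of > 50000 nM in this assay, at which 2 of the 3 values shown sit. Compound 4 `CCn1c(C(=O)N[C@H](CCC(=O)O)C(=O)O)ccc1C(CC)(CC)c1ccc(OCS(=O)(=O)c2ccccc2)c(C)c1` remains to be measured. It differs from compound 2 in one place: 1,3-dicarboxypropyl in place of 1-(hydroxymethyl)-2-methylpropyl on an amide-type nitrogen. The nearest measured step is an at least 2.6-fold higher number from compound 2 to compound 3 (0.42 log units; beyond the scatter), where a dicarboxy group also replaced the 1-(hydroxymethyl)-2-methylpropyl group; an at least 2.6-fold lower number from compound 1 to compound 2 (0.42 log units; beyond the scatter) runs the other way. A rise beyond the scatter is therefore expected, a 3.2-fold higher number from compound 2 to compound 4 (0.50 log units; beyond the scatter), most likely reaching the limit. Compound 4 is estimated at 60000 nM, within 20000 nM to 200000 nM.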

Compound 4, half-maximal inhibitory concentration: > 50000 nM
Compound 4 gave a limit, no number; the forecaster's own chance of this, stated with the estimate: 70%; the middle value does not contradict the limit.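

In this assay, the change from 1-(hydroxymethyl)-2-methylpropyl to 1,3-dicarboxypropyl gives an at least 2.6-fold higher number from compound 2 to compound 4 (0.42 log units; beyond the scatter), so a second dicarboxy group on this amide-type nitrogen now shows the same kind of rise as compound 3. The steps from compound 1 and compound 3 to compound 4 cannot be read, which leaves the two dicarboxy groups and the (methoxycarbonyl)methyl group unranked. Compound 4 is a limit, not a number, and joins compound 1 and compound 3 there: the limit of > 50000 nM in this assay, at which 3 of the 4 values shown sit.

From the compounds shown here alone, whether a single carboxylic acid, an amine or a longer hydroxyalkyl chain at this position would give a readable number remains open. For the compounds shown here, compound 2 remains the only compound with a number, so no ranking among substituents can yet be drawn.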